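A few compounds are considered here, and "the series" means these few. Any claim that something is new, unique, unknown or untested is made for them only; others in the source may bear on it.

Compound 1 (`FC(F)(F)c1ccc(Nc2nccc(-c3cnc4ccccc4c3)n2)cc1`) reads > 50000 nM in a functional assay on MCF7 cells (Homo sapiens) for cytotoxicity, read by sulforhodamine B assay, with a stated time of 48 h (on this read-out lower numbers stand for stronger inhibition and higher numbers for weaker inhibition), and that figure is a limit of the assay, not a number. Compound 1 therefore stands at the limit of > 50000 nM in this assay, at which 1 of the 2 values shown sits, and offers no measured potency as a starting point. In this assay compound 2 (`FC(F)(F)c1ccc(Nc2nccc(-c3ccnc4ccccc34)n2)cc1`) gives 1650 nM as a measured number.

Compound 3 (`Cc1ccc(Nc2nccc(-c3cnc4ccccc4c3)n2)cc1`) shares the core of compound 1 and changes in one place only (methyl in place of trifluoromethyl on an aromatic carbon), with methyl in place of trifluoromethyl on an aromatic carbon, para to a large group. Among the measured compounds shown here, no measured step shows what this exchange does in this assay and the only guide is the limit of compound 1 (> 50000 nM). The step is expected to be small and, if it can be seen at all, to run toward lower numbers, with an at least 1.2-fold lower number from compound 1 to compound 3 (0.09 log units; that floor lies within the scatter) as the estimate. Compound 3 is expected at 40000 nM (estimated range 12000 nM to 80000 nM) and may well be reported only as a limit.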

Compound 3, half-maximal inhibitory concentration: 50000 nM
For compound 3 the middle estimate is 1.3-fold (0.10 log units) below the measured one; the measured number falls inside the stated range.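

Compound 1 has only a limit in this assay, > 50000 nM, and that figure is not a number. Exchanging trifluoromethyl for methyl on an aromatic carbon, para to a large group, gives a number no higher from compound 1 to compound 3 (the limit leaves the size open), so at this position neither group brings the core of compound 1 clear of the top of the values seen: the limit of > 50000 nM in this assay, at which 1 of the 3 values shown sits. What this adds is that replacing a group of four heavy atoms with a single carbon here, with no hydrogen-bond donor or acceptor entering or leaving, produces no gain that can be sized.

On these data alone, whether any other group at this carbon would move the read-out stays open, since an amine, a methoxy group or a chlorine atom could behave differently from both methyl and trifluoromethyl. As far as these compounds go, it also stays open whether methyl in place of trifluoromethyl would do the same on the core of compound 2, which has a measured number from which a step could be read in size.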